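The source may report more compounds than this note shows. Statements on the series, on what has been measured and on what is new or still open speak of the compounds shown alone.

In an ADME assay on Caecum (Rattus norvegicus, strain Sprague-Dawley) for metabolic stability, read by LC-MS, tested at 10 uM (on this read-out higher numbers stand for a longer-lived compound and lower numbers for a shorter-lived compound), compound 1 `C[C@@H](N[C@H]1CCN(c2ccc(S(=O)(=O)NC(=O)CCC(=O)O)cc2)C1)c1cccc2ccccc12` gives 10.5 h, the higher of the two numbers available, and compound 2 `C[C@@H](N[C@H]1CCN(c2ccc(C(=O)NCCS(=O)(=O)O)cc2)C1)c1cccc2ccccc12` gives 0.8 h. Compound 3 `C[C@@H](N[C@H]1CCN(c2ccc(C(=O)NCCCN3CCC(C(=O)O)CC3)cc2)C1)c1cccc2ccccc12` reads > 12 h in this assay, which is a limit of the assay and not a number.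

The step to compound 4 `C[C@@H](N[C@H]1CCN(c2ccc(C(=O)N[C@H](CC(=O)O)C(=O)O)cc2)C1)c1cccc2ccccc12` changes the group on an aromatic carbon of a six-membered aromatic ring of carbon only, para to a large group: (1,2-dicarboxyethyl)carbamoyl in place of ((2-carboxyethyl)carbonyl)sulfamoyl on an aromatic carbon. (1,2-dicarboxyethyl)carbamoyl stands in place of ((2-carboxyethyl)carbonyl)sulfamoyl.

Among the measured compounds shown here, two measured steps bear on this. The change at the same carbon, a 13-fold lower number from compound 1 to compound 2 (1.12 log units; beyond the scatter), is large and beyond the scatter, and it brings in (2-sulfoethyl)carbamoyl. The next, an at least 15-fold higher number from compound 2 to compound 3 (1.17 log units; beyond the scatter), is also large and beyond the scatter, and it replaces sulfo with (4-carboxypiperidin-1-yl)methyl. Compound 2 and compound 3 share the carbamoyl link yet sit far apart, so that link alone does not mark the low number. Compound 4 has no sulfo, so the large fall seen for compound 2 at 0.8 h is not expected to carry over.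

No step beyond the scatter is expected in this assay, and the estimated step is a 1.5-fold lower number from compound 1 to compound 4 (0.18 log units; within the scatter). The estimate for compound 4 is 7 h, with an expected range of 2 h to 12 h.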

Compound 4, half-life: 9.1 h
Compound 4: middle estimate off by 1.3-fold (0.11 log units), on the low side; the range from low to high includes it.
By their numbers in this assay, from the lowest: compound 2; then compounds 4 and 1 (each within the scatter of the next). At a limit, above all of these: compound 3.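

At this aromatic carbon, para to a large group, (1,2-dicarboxyethyl)carbamoyl in place of ((2-carboxyethyl)carbonyl)sulfamoyl gives in this assay a 1.2-fold lower number from compound 1 to compound 4 (0.06 log units; within the scatter), so the two groups cannot be told apart here. On the amide-type nitrogen, 1,2-dicarboxyethyl in place of 2-sulfoethyl gives an 11-fold higher number from compound 2 to compound 4 (1.06 log units; beyond the scatter), so a carbamoyl compound without the sulfo group now has a measured number well clear of compound 2, where the earlier comparison with compound 3 gave only a limit. Compound 3 reads > 12 h, which is a limit of the assay and not a number: the limit of > 12 h in this assay, at which 1 of the 4 values shown sits. On the same amide-type nitrogen, 1,2-dicarboxyethyl in place of 3-(4-carboxypiperidin-1-yl)propyl gives an at least 1.3-fold lower number from compound 3 to compound 4 (0.12 log units; that floor lies within the scatter).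

On these data alone, whether the short half-life of compound 2 goes with the sulfo group itself or with the 2-sulfoethyl chain as a whole stays open, and a plain 2-carboxyethyl group on the same amide-type nitrogen, with a single carboxylic acid, would bear on that. Also open is whether the defined stereocentre of the 1,2-dicarboxyethyl group has any bearing on the number, since the mirror-image form of that group lies outside the compounds shown.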